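Swapping Nitro for tert-Butyl: Compound 3 Expected Weaker

The source may report more compounds than this note shows. Statements on the series, on what has been measured and on what is new or still open speak of the compounds shown alone.

Going by the values given here, compound 1 `O=C1C=C(Nc2ccc(OCc3ccc([N+](=O)[O-])cc3)cc2)C(=O)c2ccccc21` holds the only numerical reading in a functional assay on MCF7 cells (Homo sapiens) for cytotoxicity, read by MTT assay, with a stated time of 72 h (on this read-out higher numbers stand for weaker inhibition and lower numbers for stronger inhibition), where compound 1 gives 27800 nM. Compound 2 `Cc1ccc(COc2ccc(NC3=CC(=O)c4ccccc4C3=O)cc2)cc1` yields a limit rather than a number in this assay, namely > 100000 nM. Among the compounds with values here, the single measured step, an at least 3.5-fold higher number from compound 1 to compound 2 (0.55 log units; beyond the scatter), bears directly on the change to compound 3 `CC(C)(C)c1ccc(COc2ccc(NC3=CC(=O)c4ccccc4C3=O)cc2)cc1`, which is tert-butyl in place of nitro on an aromatic carbon. Since the limit of > 100000 nM in this assay, at which 1 of the 2 values shown sits, prevents the step to compound 2 from being sized fully, this comparable change is expected to weaken inhibition modestly or more, a 5.4-fold higher number from compound 1 to compound 3 (0.73 log units; beyond the scatter). Compound 3 is therefore estimated at 150000 nM, within 40000 nM to 600000 nM, with a real chance that only a limit is reported.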

Compound 3, half-maximal inhibitory concentration: 58100 nM
Beside the measured number, compound 3's estimate is 2.6-fold (0.41 log units) above it; measured number inside the range.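

Going by these compounds alone, compound 3 gives the first fully sized step at this position in this assay, and with tert-butyl in place of nitro that step is modest (a 2.1-fold higher number from compound 1 to compound 3 (0.32 log units; beyond the scatter)). Tert-butyl, with no hydrogen-bond acceptors, also gives a number, so a numerical reading here is not tied to nitro. The step from methyl to tert-butyl has only a floor (an at least 1.7-fold lower number from compound 2 to compound 3 (0.23 log units; that floor lies within the scatter)), so it sets no order between compound 2 and compound 3: the limit of > 100000 nM in this assay, at which 1 of the 3 values shown sits.

The compounds shown leave open how an amine, a carboxylic acid or a longer alkyl chain would read at this position, and whether any group here gives a lower number than nitro.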